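The source may report more compounds than this note shows. Statements on the series, on what has been measured and on what is new or still open speak of the compounds shown alone.

Working notes on the series. Compound 2 `COc1ccc2cc(C(C)c3nnc4n3N=C(c3ccc(C(F)(F)F)cc3)CS4)ccc2c1` carries the methoxynaphthyl side and a trifluoromethyl on the shared core; in a functional assay on MCF7 cells (Homo sapiens) for inhibition, read by sulforhodamine B assay, with a stated time of 72 h (a higher number here means a weaker inhibitor, a lower number a stronger inhibitor), compound 2 gives 6900 nM. Compound 1 `CC(c1ccc(-c2ccccc2)c(F)c1)c1nnc2n1N=C(c1ccc(OC(F)(F)F)cc1)CS2` gives 4800 nM in this assay. Of the two numbers shown, that of compound 2 is the larger, but the difference from compound 1 lies within the usual scatter, so the two are to be read as equivalent. Compound 3 `COc1ccc2cc(C(C)c3nnc4n3N=C(c3ccc(OC(F)(F)F)cc3)CS4)ccc2c1` is the unmeasured partner of compound 2; the change is trifluoromethoxy in place of trifluoromethyl on an aromatic carbon. Among the measured compounds shown here, no measured pair isolates this change, so its size cannot be taken from a measured step; compound 1 carries trifluoromethoxy but differs elsewhere as well. The expected step of a 1.2-fold lower number from compound 2 to compound 3 (0.06 log units; within the scatter) is therefore set at none beyond the scatter, with no direction assigned. Compound 3 is expected at 6000 nM, within a range of 2500 nM to 14000 nM.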

Compound 3, half-maximal inhibitory concentration: 8800 nM
Compound 3: the middle estimate sits 1.5-fold (0.17 log units) below what was measured; low and high end bracket the measured number.
By their numbers in this assay, from the lowest: compounds 1, 2 and 3 (each within the scatter of the next).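

Among the compounds shown here, this pair gives the first measured reading of the change on the shared core: in this assay, with the methoxynaphthyl side held constant, trifluoromethoxy in place of trifluoromethyl on the aromatic carbon para to a large group gives a 1.3-fold higher number from compound 2 to compound 3 (0.11 log units; within the scatter). At this position and with this side, the two groups therefore cannot be told apart in this assay, and the added oxygen, counted as one hydrogen-bond acceptor, brings no step beyond the scatter. Nothing available gives a reason for this outcome or a measured property of either group.

The compounds shown leave open whether the same change reads alike with the side carried by compound 1. Also open, on these data alone, is whether a group of another kind at this position, such as an amine, a carboxylic acid or a nitrile, would move the number beyond the scatter.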